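The source may hold more compounds than are shown below. What is called first, only, known or untested is meant among the compounds shown, and "the series" means these compounds.

Compound 2 `O=c1ccn(CCCCCOc2ccc(Cl)cc2)c(=O)[nH]1` stands at the upper end of the numbers shown in an ADME assay on HEL cells (Homo sapiens) for cytotoxicity, read by microscopy; on this read-out higher numbers stand for lower toxicity in this test and lower numbers for higher toxicity in this test. In this assay compound 2 gives > 100000 nM, which is a limit of the assay and not a number. Compound 1 `CC(C)(C)c1ccc(OCCCCCn2ccc(=O)[nH]c2=O)cc1` in this assay gives 100000 nM. The step of a number no lower from compound 1 to compound 2 (the limit leaves the size open) is left open in size because of the limit of > 100000 nM in this assay, at which 1 of the 2 values shown sits. Compound 3 `O=c1ccn(CCCCCOc2ccccc2)c(=O)[nH]1` differs from compound 2 by hydrogen in place of chloro on an aromatic carbon. Going by the values given here, no measured step covers this change, and the single measured step is itself open, so no change beyond the scatter is expected for compound 3 in this assay, the expected step being a number no higher from compound 2 to compound 3 (the limit leaves the size open). Compound 3 is estimated at 100000 nM, within 50000 nM to 200000 nM.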

Compound 3, minimum cytotoxic concentration: > 100000 nM
Compound 3 gave a limit, no number; the forecaster's own chance of this, stated with the estimate: 60%; the middle value sits exactly at the limit.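

In this assay compound 3 gives > 100000 nM, which is a limit of the assay and not a number. Compound 2 also sits at a limit, so the change from 4-chlorophenyl to phenyl cannot be read, while the change from tert-butyl to hydrogen gives a number no lower from compound 1 to compound 3 (the limit leaves the size open). Chloro and hydrogen on this aromatic carbon thus both end at the top of the range, and the position has no readable order for these two groups: the limit of > 100000 nM in this assay, at which 2 of the 3 values shown sit.

As far as these compounds go, whether an amine or a carboxylic acid on this aromatic carbon would give a number rather than a limit stays open. From the compounds shown here alone, the reading for a longer chain stays open as well.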